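Adding a methylpiperazine group to the amine of compound 2

The compounds below may be only part of what the source reports. "The series", "measured", "known", "first", "only" and "open" are said of these compounds alone.

In an ADME assay on L6 cells (Rattus norvegicus) for cytotoxicity, read by resazurin assay, with a stated time of 72 h (a higher number here means a weaker inhibitor, a lower number a stronger inhibitor), compound 2 (`NC1CC2(N3CCCCC3)CC(c3ccccc3)C1C(c1ccccc1)C2`) gives 35000 nM as its half-maximal inhibitory concentration. Among the measured compounds shown here, the only other measured compound, compound 1 (`CN1CCN(CC(=O)NC2CC3(N(C)C)CC(c4ccccc4)C2C(c2ccccc2)C3)CC1`), gives 66200 nM in this assay and the two values lie within the usual scatter of each other, so the numbers do not separate compound 2 from compound 1. Compound 3 (`CN1CCN(CC(=O)NC2CC3(N4CCCCC4)CC(c4ccccc4)C2C(c2ccccc2)C3)CC1`) carries ((4-methylpiperazin-1-yl)methyl)carbonyl in place of hydrogen on an amine nitrogen of compound 2 (((4-methylpiperazin-1-yl)methyl)carbonyl in place of hydrogen on an amine nitrogen). For the measured compounds named here, no measured step shows the effect of this change. Compound 1 also carries that group and gives 66200 nM in the same range as compound 2, so no shift beyond the scatter is expected in this assay. The expected change is small (a 1.1-fold higher number from compound 2 to compound 3 (0.06 log units; within the scatter)). The estimate for compound 3 is 40000 nM within an expected range from 13000 nM to 120000 nM on repeat testing.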

Compound 3, half-maximal inhibitory concentration: 57500 nM
Compound 3: the middle estimate sits 1.4-fold (0.16 log units) below what was measured; the range from low to high includes it.
By their numbers in this assay, from the lowest: compounds 2, 3 and 1 (each within the scatter of the next).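

In this assay, the amine nitrogen of compound 2 now has a measured step of its own: ((4-methylpiperazin-1-yl)methyl)carbonyl in place of hydrogen lies within the scatter (a 1.6-fold higher number from compound 2 to compound 3 (0.22 log units; within the scatter)). With that group present on the amine nitrogen, a second single change, piperidin-1-yl in place of dimethylamino on a saturated ring carbon, also lies within the scatter (a 1.2-fold lower number from compound 1 to compound 3 (0.06 log units; within the scatter)), so neither step separates the compounds it joins. Nothing available here bears on these results.

The compounds shown leave open whether a different group on this amine nitrogen, such as a plain acetyl or a carboxylic acid, would give a step beyond the scatter. They also leave open whether a longer chain between the carbonyl and the 4-methylpiperazin-1-yl ring would do so.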